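Swapping Methoxy for Chloro on a Longer Chain

This account rests on a few compounds, and the source may have more. Where it says the series, first, only, none or still open, it means among the compounds named here.

The three compounds measured so far are:
compound 1, `COc1ccccc1N1CCN(CCn2nc(N3CCN(C(=O)c4ccco4)CC3)ccc2=O)CC1`, which in an assay on cell membranes for binding affinity to Adrenergic receptor alpha-1 (Rattus norvegicus), read by radioligand binding (on this read-out higher numbers stand for weaker inhibition and lower numbers for stronger inhibition), gives 94.5 nM;
compound 2, `O=C(c1ccco1)N1CCN(c2ccc(=O)n(CCN3CCN(c4ccccc4Cl)CC3)n2)CC1`, which in this assay gives 34 nM;
compound 3, `COc1ccccc1N1CCN(CCCCCn2nc(N3CCN(C(=O)c4ccco4)CC3)ccc2=O)CC1`, which in this assay gives 43.7 nM.

Compound 4, `O=C(c1ccco1)N1CCN(c2ccc(=O)n(CCCCCN3CCN(c4ccccc4Cl)CC3)n2)CC1`, has not been measured. It differs from compound 3 by one change: chloro in place of methoxy on an aromatic carbon. The same change links two compounds that are already measured, compound 1 and compound 2, where it reads chloro in place of methoxy on an aromatic carbon and produced a 2.8-fold lower number from compound 1 to compound 2 (0.44 log units; beyond the scatter). The place of the change is described in the same words in both pairs, so this is the same change made on a second core; how the core of compound 3 differs from that of compound 1 is not broken down here. Compound 3 and compound 2 give numbers within the scatter of each other, while compound 1 gives a higher number than compound 3. Going by the values given here, with only one earlier instance of this change to go on, for compound 4 a step of similar size is expected, a 2.7-fold lower number from compound 3 to compound 4 (0.44 log units; beyond the scatter), because the same change gave a 2.8-fold lower number from compound 1 to compound 2 (0.44 log units; beyond the scatter). On that basis compound 4 is estimated at 16 nM in this assay, most likely between 7 nM and 40 nM.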

Compound 4, inhibition constant: 13.3 nM
The estimate for compound 4 lay 1.2-fold (0.08 log units) above the measured number, within the range that was stated.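

In this assay, putting chloro in place of methoxy on the longer-chain core gave a 3.3-fold lower number from compound 3 to compound 4 (0.52 log units; beyond the scatter), a step in the same direction as the one seen earlier on the core of compound 1. The two steps match closely in size: the same change on two cores in this assay, a 2.8-fold lower number (0.44 log units; beyond the scatter) from compound 1 to compound 2 and a 3.3-fold lower number (0.52 log units; beyond the scatter) from compound 3 to compound 4, 1.2-fold (0.07 log units) apart, within the scatter of two such steps. This shows that, across these two pairs, the change carried from one core to the other with little alteration in its size, but two pairs are too few to make a rule for the whole series, and they do not explain why the number falls or show how the change behaves on any other core or in any other read-out.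

The compounds shown leave open whether another group in the same place, such as fluoro, methyl or nitrile, would give a similar step, and whether chloro would do so at another place on the ring. They also leave open whether the step would hold with a still longer chain.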